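Benzofuran for Furan on Two Nucleoside Cores

A few compounds are considered here, and "the series" means these few. Any claim that something is new, unique, unknown or untested is made for them only; others in the source may bear on it.

Compound 1 `O=c1[nH]cnc2c1c(-c1ccoc1)cn2[C@@H]1O[C@H](CO)[C@@H](O)[C@H]1O` gives 14800 nM in a functional assay on HCT-116 cells (Homo sapiens), read by MTT assay, with a stated time of 72 h; a higher number here means a weaker inhibitor, a lower number a stronger inhibitor. Compound 2 `Cc1nc(N)c2c(-c3ccoc3)cn([C@@H]3O[C@H](CO)[C@@H](O)[C@H]3O)c2n1` gives only a limit of the assay, > 20000 nM, in this assay. Compound 3 `O=c1[nH]cnc2c1c(-c1cc3ccccc3o1)cn2[C@@H]1O[C@H](CO)[C@@H](O)[C@H]1O` likewise gives only a limit, > 20000 nM, in this assay.

Compounds 1 and 3 differ by one change, (1-benzofuran-2-yl in place of furan-3-yl on an aromatic carbon), and the step is an at least 1.3-fold higher number from compound 1 to compound 3 (0.13 log units; that floor lies within the scatter). Its true size is hidden because compound 3 sits at the limit of > 20000 nM in this assay, at which 2 of the 3 values shown sit. Compound 2 carries a different core; the difference between the two cores is not broken down here. Compound 4 `Cc1nc(N)c2c(-c3cc4ccccc4o3)cn([C@@H]3O[C@H](CO)[C@@H](O)[C@H]3O)c2n1` has not yet been measured in this assay; it arises from compound 2 by the same change, (1-benzofuran-2-yl in place of furan-3-yl on an aromatic carbon), and the surroundings of the change are the same in both pairs.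

The step from compound 2 to compound 4 is expected to be a step that the limit leaves unreadable from compound 2 to compound 4, and this rests on compound 2 already standing at the limit of > 20000 nM in this assay, at which 2 of the 3 values shown sit, while the measured pair gave no gain. For compound 4 the expected value in this assay is 35000 nM. For compound 4 the expected range runs from 15000 nM to 90000 nM.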

Compound 4, half-maximal inhibitory concentration: 13100 nM
Compound 4: the middle estimate sits 2.7-fold (0.43 log units) above what was measured; the measured number lies below the stated range.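

In this assay, putting 1-benzofuran-2-yl in place of furan-3-yl on the second core gives an at least 1.5-fold lower number from compound 2 to compound 4 (0.18 log units; that floor lies within the scatter), and compound 4 returns a real number where compound 2 returned only a limit. This shows that the larger group does not rule out a readable value on this core, but it does not show that the change works better here than on the core of compound 1, as each step is known only as a floor that lies within the usual scatter, and the comparison stays unsettled: the same change on two cores in this assay, an at least 1.3-fold higher number (0.13 log units; that floor lies within the scatter) from compound 1 to compound 3 and an at least 1.5-fold lower number (0.18 log units; that floor lies within the scatter) from compound 2 to compound 4; the limit leaves it open whether they differ. Nor does it show that the change carries over, or fails to carry over, from one core to the other, as some of the values shown are limits rather than numbers: the limit of > 20000 nM in this assay, at which 2 of the 4 values shown sit.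

From the compounds shown here alone, the true size of both steps remains open. Also open, going by these compounds, is how other groups in the same place, such as phenyl, thiophene or a benzofuran carrying an amine, would behave on these two cores.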